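The compounds below may be only part of what the source reports. "The series", "measured", "known", "first", "only" and "open" are said of these compounds alone.

Measured so far in an assay on isolated protein for inhibition of Rho-associated protein kinase 2 (Homo sapiens), read by scintillation counting, radiometric assay and 33P incorporation, with a stated time of 40 min, in the presence of a further agent that is not named here; a lower number here means a stronger inhibitor, a higher number a weaker inhibitor:
- compound 1 `COc1ccc(OCC(=O)Nc2cccc(NC(=O)c3ccc(N(C)C)cc3)c2)cc1F` gives 652 nM
- compound 2 `CN(C)c1ccc(C(=O)Nc2cccc(NC(=O)COc3ccc4c(c3)OCCO4)c2)cc1` gives > 10000 nM, which is a limit of this assay and not a number
- compound 3 `CCCc1ccc(C(=O)Nc2cccc(NC(=O)COc3ccc4c(=O)ccoc4c3)c2)cc1` gives 14 nM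

Compound 3 stands lowest of the two numbers, with compound 1 the nearest. Going by the values given here, the only step measured between two compounds, an at least 15-fold higher number from compound 1 to compound 2 (1.18 log units; beyond the scatter), changes the ring on the oxygen on a saturated carbon, the far end of the shared core, and compound 2 sits at the limit of > 10000 nM in this assay, at which 1 of the 3 values shown sits.

Compound 4 `O=C(COc1ccc2c(=O)ccoc2c1)Nc1cccc(NC(=O)c2cnc(C(F)(F)F)s2)c1` differs from compound 3 elsewhere: 2-(trifluoromethyl)-1,3-thiazol-5-yl in place of 4-propylphenyl on a carbonyl carbon. Among the compounds with values here, no measured step touches that position, so the expectation rests on compound 3 alone with a wide range. Compound 4 is estimated at 60 nM, between 10 nM and 400 nM, an expected step of a 4.3-fold higher number from compound 3 to compound 4 (0.63 log units; beyond the scatter).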

Compound 4, half-maximal inhibitory concentration: 10 nM
For compound 4 the middle estimate is 6.0-fold (0.78 log units) above the measured one; the measured number falls inside the stated range.
By their numbers in this assay, from the lowest: compounds 4 and 3 (each within the scatter of the next); then compound 1. At a limit, above all of these: compound 2.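

Putting 2-(trifluoromethyl)-1,3-thiazol-5-yl in place of 4-propylphenyl on a carbonyl carbon gives a 1.4-fold lower number from compound 3 to compound 4 (0.15 log units; within the scatter) in this assay. With this shared core, then, a five-membered aromatic ring with 2 hetero atoms does as well here as a six-membered aromatic ring of carbon only. No measurement shown bears on why these two groups read alike.

As far as these compounds go, whether an amine or a carboxylic acid on this carbonyl carbon would keep the number this low remains open. So does whether the thiazole group would do as well with 3-fluoro-4-methoxyphenyl at the far end.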